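Alkoxy chain length and antiproliferative activity across the series

A few compounds are considered here, and "the series" means these few. Any claim that something is new, unique, unknown or untested is made for them only; others in the source may bear on it.

Measured compounds:
compound 1, `CCCCOC1(c2ccc(Br)cc2)SC=C(C)n2c1noc2=O`: 82000 nM
compound 2, `CCCCCCCCCCCCCCCOC1(c2ccc(Cl)cc2)SC=C(C)n2c1noc2=O`: > 100000 nM
compound 3, `CCCCCCCCCCCCCCCCCCOC1(c2ccc(Cl)cc2)SC=C(C)n2c1noc2=O`: > 100000 nM

Compound 2, `CCCCCCCCCCCCCCCOC1(c2ccc(Cl)cc2)SC=C(C)n2c1noc2=O`, stands at the assay limit: in a functional assay on A2780 cells (Homo sapiens) for antiproliferative activity, read by MTT assay, with a stated time of 3 days (a higher number here means a weaker inhibitor, a lower number a stronger inhibitor), compound 2 gives > 100000 nM, which is a limit and not a number. Compound 3, `CCCCCCCCCCCCCCCCCCOC1(c2ccc(Cl)cc2)SC=C(C)n2c1noc2=O`, likewise returns only a limit in this assay, > 100000 nM. For the measured compounds named here, the single measured step, a step that the two limits leave unreadable from compound 2 to compound 3, is therefore unreadable, a consequence of the limit of > 100000 nM in this assay, at which 2 of the 3 values shown sit. Going by the values given here, compound 1, `CCCCOC1(c2ccc(Br)cc2)SC=C(C)n2c1noc2=O`, is the one compound with a number in this assay, where compound 1 gives 82000 nM.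

Compound 4, `CCCCCOC1(c2ccc(Cl)cc2)SC=C(C)n2c1noc2=O`, differs from compound 2 by hydrogen in place of decyl on a saturated chain carbon, five bonds along the chain from an oxygen on a saturated carbon. Among the compounds with values here, no measured step bears on this change; the two limits show only that the two long-chain compounds give no readable inhibition. Compound 1, carrying a short chain, gives a number that sits close to the limit. Compound 4 is therefore expected to land near that number, with the step from compound 2 estimated as an at least 1.2-fold lower number from compound 2 to compound 4 (0.09 log units; that floor lies within the scatter). The estimate for compound 4 is 80000 nM, in the range 35000 nM to 150000 nM, with a fair chance that only a limit is reported.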

Compound 4, half-maximal inhibitory concentration: > 100000 nM
Compound 4 ended at the assay's limit (the forecaster's own chance of this, stated with the estimate: 40%); middle value at least 1.2-fold (0.09 log units) from the limit.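

Compound 4 gives > 100000 nM in this assay, which is a limit and not a number. No step can be read from compound 2 to compound 4, because both return only a limit: the limit of > 100000 nM in this assay, at which 3 of the 4 values shown sit.

The compounds shown leave open whether changing the chain length moves the value in this assay at all.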